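A few compounds are considered here, and "the series" means these few. Any claim that something is new, unique, unknown or untested is made for them only; others in the source may bear on it.

In an ADME assay on microsomes from liver (Rattus norvegicus) for metabolic stability, read by LC-MS, using NADPH, at 37 degrees C (a higher number here means that the compound lasts longer, a lower number that the compound disappears faster), compound 1 `Cc1cc(C)c(-c2nc(CN3CCC(C(=O)NCCCN4C[C@H](C)C[C@H](C)C4)CC3)c(C)o2)c(C)c1` gives > 0.5 h, a limit and not a number; this is the limit of > 0.5 h in this assay, at which 2 of the 3 values shown sit. Compound 3 `Cc1ccccc1-c1nc(CN2CCC(C(=O)NCCCN3CCC(C)CC3)CC2)c(C)o1` gives > 0.5 h, also a limit. Compound 2 `CC[C@@H]1C[C@H](CC)CN(CCCNC(=O)C2CCN(Cc3nc(-c4ccccc4C)oc3C)CC2)C1` gives 0.0917 h. Compound 4 `Cc1oc(-c2c(F)cccc2F)nc1CN1CCC(C(=O)NCCCN2C[C@H](C)C[C@H](C)C2)CC1` differs from compound 1 by 2,6-difluorophenyl in place of 2,4,6-trimethylphenyl on an aromatic carbon, with 2,6-difluorophenyl in place of 2,4,6-trimethylphenyl on an aromatic carbon. Going by the values given here, the only measured step, an at least 5.4-fold higher number from compound 2 to compound 3 (0.73 log units; beyond the scatter), exchanges a different group, the substituted piperidine, so it gives no size for this change. Among the compounds with values here, with no measured step on this aromatic group, the expected step is a number no higher from compound 1 to compound 4 (the limit leaves the size open), an estimate of no change beyond the scatter in this assay. Compound 4 is expected at 0.5 h, with an estimated range from 0.2 h to 1 h.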

Compound 4, half-life: 0.35 h
For compound 4 the middle estimate is 1.4-fold (0.15 log units) above the measured one; low and high end bracket the measured number.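

In this assay, the exchange of 2,4,6-trimethylphenyl for 2,6-difluorophenyl now has a step of its own: an at least 1.4-fold lower number from compound 1 to compound 4 (0.15 log units; that floor lies within the scatter). Compound 4 gives a true number at this position, 0.35 h. On these data alone, the full size of the step stays unknown, because compound 1 rests on a limit: the limit of > 0.5 h in this assay, at which 2 of the 4 values shown sit.

The compounds shown leave open whether this exchange goes beyond the scatter at all. They also leave open how an unsubstituted phenyl or a 2,6-dichlorophenyl would read here, and whether the exchange holds with 4-methylpiperidin-1-yl on the chain.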